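Exchanging the Aryl Group on the Sulfonyl Sulfur

A few compounds are considered here, and "the series" means these few. Any claim that something is new, unique, unknown or untested is made for them only; others in the source may bear on it.

Measured compounds:
Compound 1, `Cc1ccc(S(=O)(=O)c2cnc3cc(Cl)ccc3c2N2CCC(C)CC2)cc1C`: 86%
Compound 2, `CC1CCN(c2c(S(=O)(=O)c3cccc(C#N)c3)cnc3cc(Cl)ccc23)CC1`: 94%

In an assay on isolated protein for displacement of a labelled ligand from metabotropic glutamate receptor 5 (Homo sapiens), with a stated time of 60 min, tested at 1 uM (a higher number here means more inhibition at the concentration tested (going by the name of the read-out), a lower number less inhibition), compound 1 gives 86%, and compound 2 gives 94%. Going by the values given here, compound 2 carries the larger of the two numbers, but the only step available, a number 8 percentage points higher from compound 1 to compound 2 (within the scatter), lies within the scatter, so the two compounds cannot be told apart on these data.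

Compound 3, `CC1CCN(c2c(S(=O)(=O)c3ccc(Cl)c(Cl)c3)cnc3cc(Cl)ccc23)CC1`, differs from compound 2 in one place: 3,4-dichlorophenyl in place of 3-cyanophenyl on a sulfonyl sulfur. Among the compounds with values here, the single measured step also exchanged the aryl group on the sulfonyl sulfur and was a number 8 percentage points higher from compound 1 to compound 2 (within the scatter), so the one precedent shows that such an exchange left the read-out essentially unchanged. On that basis the step from compound 2 to compound 3 in this assay is expected to be a number 6 percentage points lower from compound 2 to compound 3 (within the scatter), nothing beyond the scatter. The estimate for compound 3 is 88%, with a range from 70% to 99%.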

Compound 3, a percentage reported as inhibition, at one concentration (the size of the read-out at that concentration, not a potency): 89%
Compound 3: middle estimate off by 1 percentage points, on the low side; the measured number falls inside the stated range.
By their numbers in this assay, from the lowest: compounds 1, 3 and 2 (each within the scatter of the next).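

In this assay the exchange of 3-cyanophenyl for 3,4-dichlorophenyl on the sulfonyl sulfur gives a number 5 percentage points lower from compound 2 to compound 3 (within the scatter) and the exchange of 3,4-dimethylphenyl for 3,4-dichlorophenyl gives a number 3 percentage points higher from compound 1 to compound 3 (within the scatter) so all three pairs among these compounds now lie within the scatter. A third aryl group, this one carrying two chlorines, thus joins the nitrile and dimethyl versions without separating from either, and at this position the three groups cannot be told apart. No measurement shown here accounts for this sameness.

As far as these compounds go, whether an aryl group bearing a carboxylic acid or an amine, or a simple methyl or a cyclohexyl on the sulfonyl sulfur in place of the aryl group, would keep the read-out where these three stand remains open. Any difference in potency among the three also remains open, since a percentage at one concentration is not a potency.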